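The source may hold more compounds than are shown below. What is called first, only, known or untested is meant among the compounds shown, and "the series" means these compounds.

Of the compounds shown here, three that share one core have been measured in an ADME assay on Vero cells (Chlorocebus sabaeus) for cytotoxicity, read by MTT assay, with a stated time of 2 days; on this read-out lower numbers stand for stronger inhibition and higher numbers for weaker inhibition. Compound 1 `C=CCCC(=O)Nc1cc2nc(C3CCCCC3)[nH]c2cc1Oc1ccc(F)cc1` reaches only the limit of the assay, reported as > 200000 nM. Compound 2 `CCCCSc1cc2[nH]c(C3CCCCC3)nc2cc1NC(=O)OCCC` gives 75000 nM, and compound 3 `COc1ccc(C(=O)Nc2cc3nc(C4CCCCC4)[nH]c3cc2Oc2ccc(F)cc2)cc1` gives 40000 nM; these two numbers lie within the usual scatter of each other, so compound 2 simply stands beside compound 3. Compound 4 `CCCCSc1cc2[nH]c(C3CCCCC3)nc2cc1NC(=O)c1ccc(F)cc1F` differs from compound 2 by 2,4-difluorophenyl in place of propoxy on a carbonyl carbon. For the measured compounds named here, the one measured step of similar kind, an aromatic ring replacing a chain on the carbonyl carbon, is an at least 5.0-fold lower number from compound 1 to compound 3 (0.69 log units; beyond the scatter), although it rests on (the limit of > 200000 nM in this assay, at which 1 of the 3 values shown sits). A lower number is therefore expected for compound 4, with a step of a 2.5-fold lower number from compound 2 to compound 4 (0.40 log units; beyond the scatter). Compound 4 is estimated at 30000 nM, between 10000 nM and 100000 nM.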

Compound 4, half-maximal inhibitory concentration: > 200000 nM
Compound 4: no number, only a limit; the forecaster's own chance of this, stated with the estimate: 5%; middle value at least 6.6-fold (0.82 log units) from the limit.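

In this assay, 2,4-difluorophenyl in place of propoxy on this carbonyl carbon gives an at least 2.6-fold higher number from compound 2 to compound 4 (0.42 log units; beyond the scatter), so an aromatic ring in place of a chain does not lower the number in every pair shown. The value of compound 4, > 200000 nM, is a limit and not a number. The full size of this step therefore stays unknown: the limit of > 200000 nM in this assay, at which 2 of the 4 values shown sit.

From the compounds shown here alone, it remains open whether an unsubstituted phenyl or a butyl chain at this place would follow propoxy or 2,4-difluorophenyl. Also open, going by these compounds, is how 4-methoxyphenyl would behave on the core of compound 2.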